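The source may hold more compounds than are shown below. What is called first, only, known or untested is meant among the compounds shown, and "the series" means these compounds.

Measured so far in an ADME assay on L02 cells (Homo sapiens) for cytotoxicity, read by MTT assay, with a stated time of 48 h; on this read-out higher numbers stand for weaker inhibition and lower numbers for stronger inhibition:
- compound 1 `CCn1c(C(=O)NCCCN(C)C)ccc1C(CC)(CC)c1ccc(OCC(O)C(C)(C)C)c(C)c1`: 470 nM
- compound 2 `C#CCNC(=O)c1ccc(C(CC)(CC)c2ccc(OCC(O)C(C)(C)C)c(C)c2)n1CC`: 4400 nM
- compound 3 `CC[C@@H](C)[C@H](NC(=O)c1ccc(C(CC)(CC)c2ccc(OCC(O)C(C)(C)C)c(C)c2)n1CC)C(=O)O`: 1400 nM

Not yet measured: compound 4 `CCn1c(C(=O)Oc2ccc(CCO)cc2)ccc1C(CC)(CC)c1ccc(OCC(O)C(C)(C)C)c(C)c1`.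

Of the three numbers, compound 3 stands second highest at 1400 nM. The next change lies on a carbonyl carbon: a group of 10 heavy atoms (8 carbon, 2 oxygen; one six-membered aromatic ring of carbon only) in place of a group of 9 heavy atoms (6 carbon, 1 nitrogen, 2 oxygen; no ring), on a carbonyl carbon. Two measured steps also exchange groups at this carbonyl: a 3.0-fold higher number from compound 1 to compound 3 (0.47 log units; beyond the scatter) and a 3.1-fold lower number from compound 2 to compound 3 (0.50 log units; beyond the scatter). Both are modest, and they run in opposite directions. Neither involves a group with a ring, so they suggest a size but no direction. In this assay, for the measured compounds named here, no step clearly beyond the scatter is expected, though one of similar size remains possible. The expected change is a 1.4-fold higher number from compound 3 to compound 4 (0.15 log units; within the scatter). For compound 4 the estimated value is 2000 nM, within an expected range of 600 nM to 6500 nM.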

Compound 4, half-maximal inhibitory concentration: 22700 nM
The estimate for compound 4 lay 11-fold (1.05 log units) below the measured number; the whole stated range lies below it.
By their numbers in this assay, from the lowest: compound 1; then compound 3; then compound 2; then compound 4.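

In this assay, the group with a six-membered aromatic ring of carbon only gives the highest number of the four on this carbonyl carbon, with a 16-fold higher number from compound 3 to compound 4 (1.21 log units; beyond the scatter), a 5.2-fold higher number from compound 2 to compound 4 (0.71 log units; beyond the scatter) and a 48-fold higher number from compound 1 to compound 4 (1.68 log units; beyond the scatter). The earlier exchanges here, all without a ring, stayed modest, so this position can move the number further than they showed. Nothing measured here explains the rise. Compound 4 is also the only one without nitrogen on this carbonyl carbon, so the effects of the ring and the lost nitrogen cannot be separated. An amide whose nitrogen carries a phenyl ring would be needed to tell them apart.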